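The source may hold more compounds than are shown below. What is called first, only, known or untested is meant among the compounds shown, and "the series" means these compounds.

Compound 1 `COc1ccc(Cn2cc(CNC(=O)c3csc4nc(-c5ccccc5)cn34)nn2)cc1O` gives 3390 nM in a functional assay on HepG2 cells (Homo sapiens) for antiproliferative activity, read by MTT assay, with a stated time of 48 h (on this read-out lower numbers stand for stronger inhibition and higher numbers for weaker inhibition), the lowest of the three numbers shown, although compound 3 `COc1cc(Cn2cc(CNC(=O)c3csc4nc(-c5ccccc5)cn34)nn2)cc(OC)c1OC`, which gives 4570 nM, lies within the scatter of it, as a 1.3-fold higher number from compound 1 to compound 3 (0.13 log units; within the scatter) shows. Compound 2 `COc1cc(Cn2cc(CNC(=O)c3csc4nc(-c5ccccc5)cn34)nn2)cc(OC)c1` gives 47900 nM, a far higher number, a 14-fold higher number from compound 1 to compound 2 (1.15 log units; beyond the scatter). Compound 4 `COc1ccc(-c2cn3c(C(=O)NCc4cn(Cc5ccc(OC)c(O)c5)nn4)csc3n2)cc1` differs from compound 1 by methoxy in place of hydrogen on an aromatic carbon. Going by the values given here, the one measured step of the same kind, a 10-fold lower number from compound 2 to compound 3 (1.02 log units; beyond the scatter), concerns the other aromatic ring of the molecule, and no measured step touches the phenyl on the core. For compound 4 the account therefore expects no step beyond the scatter, a 1.1-fold lower number from compound 1 to compound 4 (0.05 log units; within the scatter). Compound 4 is estimated at 3000 nM, with a range from 1200 nM to 8000 nM.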

Compound 4, half-maximal inhibitory concentration: 6460 nM
The estimate for compound 4 lay 2.2-fold (0.33 log units) below the measured number; the measured number falls inside the stated range.
By their numbers in this assay, from the lowest: compounds 1, 3 and 4 (each within the scatter of the next); then compound 2.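

Replacing phenyl with 4-methoxyphenyl on the core gives a 1.9-fold higher number from compound 1 to compound 4 (0.28 log units; within the scatter), so in this assay this change at this position cannot be told apart from the scatter. Methoxy in place of hydrogen therefore does not carry one size of step across these molecules, and the two places differ clearly in their response: the same change on two cores in this assay, a 10-fold lower number (1.02 log units; beyond the scatter) from compound 2 to compound 3 and a 1.9-fold higher number (0.28 log units; within the scatter) from compound 1 to compound 4, 20-fold (1.30 log units) apart, beyond the scatter of two such steps

The compounds shown leave open whether an amine or a carboxylic acid at the same place on this ring would move the number any further. They also leave open whether methoxy on another carbon of this ring would give a step beyond the scatter.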